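A few compounds are considered here, and "the series" means these few. Any claim that something is new, unique, unknown or untested is made for them only; others in the source may bear on it.

Compound 1 `N#CCCCn1c(Cn2c(=O)n(-c3ccncn3)c3ccncc32)cc2cc(Cl)ccc21`: > 50000 nM
Compound 2 `CC(C)(O)CCCn1c(Cn2c(=O)n(C3CC3)c3ccncc32)nc2nc(Cl)ccc21`: > 50000 nM
Compound 3 `O=c1n(Cc2cc3cnccc3n2CCCC(F)(F)F)c2cnccc2n1C1CC1`: > 50000 nM

In an ADME assay on HeLa cells (Homo sapiens) for cytotoxicity, read by ATP content, with a stated time of 3 days (on this read-out higher numbers stand for lower toxicity in this test and lower numbers for higher toxicity in this test), compound 1 gives > 50000 nM, which is a limit of the assay rather than a number. Compound 2 likewise stops at the limit > 50000 nM. Compound 3 also reaches only the limit > 50000 nM. Here (the limit of > 50000 nM in this assay, at which 3 of the 3 values shown sit), so no step between measured compounds can be sized, and compound 1 stands where the others do. Compound 4 `N#CCCCn1c(Cn2c(=O)n(-c3ccc(C(=O)NC4CC4)cc3)c3ccncc32)cc2cc(Cl)ccc21` differs from compound 1 in one place: 4-(cyclopropylcarbamoyl)phenyl in place of pyrimidin-4-yl on an aromatic nitrogen. Among the compounds with values here, with no measured step to lean on, compound 4 is expected to stay at the same limit, with the step that the limit leaves unreadable from compound 1 to compound 4 no larger than the usual scatter. Compound 4 is therefore estimated at 60000 nM, between 30000 nM and 150000 nM.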

Compound 4, half-maximal cytotoxic concentration: > 50000 nM
Compound 4 was reported as a limit; the forecaster's own chance of this, stated with the estimate: 80%; the middle value does not contradict the limit.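

The step from compound 1 to compound 4 cannot be read, because both stand at a limit: the limit of > 50000 nM in this assay, at which 4 of the 4 values shown sit. The compounds shown leave open how any one of them compares with another in this assay on a measured number.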